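The source may hold more compounds than are shown below. What is called first, only, known or untested is meant among the compounds shown, and "the series" means these compounds.

Measured so far in an ADME assay on BJ cells (Homo sapiens) for cytotoxicity, read by CellTiter-Glo and resazurin assay, with a stated time of 72 h; a higher number here means that more compound is needed for the effect, a lower number that less compound is needed:
- Compound 1 `CCOC(=O)CCCCCOc1cccc(CN(C(=O)c2ccc(-c3ccc4[nH]ccc4c3)cc2)C(C)C)c1`: > 26000 nM, a limit
- Compound 2 `CCOC(=O)CCCCCOc1cccc(CN(C(=O)c2ccc(-c3cc(OC)ccc3F)cc2)C(C)C)c1`: > 26000 nM, a limit

Compound 2 stands only at a limit, > 26000 nM, and no number is known for it. Going by the values given here, the same holds across the series so far, which offers only (the limit of > 26000 nM in this assay, at which 2 of the 2 values shown sit).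

The next compound is compound 3 `CCOC(=O)CCCCCOc1cccc(CN(C(=O)c2ccc(-c3cccc(C(F)(F)F)c3)cc2)C(C)C)c1`. It carries 3-(trifluoromethyl)phenyl in place of the 2-fluoro-5-methoxyphenyl of compound 2, on an aromatic carbon of a six-membered aromatic ring of carbon only, para to a large group: 3-(trifluoromethyl)phenyl in place of 2-fluoro-5-methoxyphenyl on an aromatic carbon.

Among the compounds with values here, one measured step bears on this change, since it exchanges a group at the same place. That step is a step that the two limits leave unreadable from compound 1 to compound 2, so its size gives no measure of how far such an exchange can move the result. Within the data shown here, with no measured step of readable size to draw on, no step beyond the scatter is expected in this assay, and no direction is expected either. The expected step is a step that the limit leaves unreadable from compound 2 to compound 3. For compound 3 the estimated value is 30000 nM, with an expected range from 15000 nM to 60000 nM.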

Compound 3, half-maximal effective concentration: < 1.3 nM
Compound 3: a limit, no number (the forecaster's own chance of this, stated with the estimate: 85%); at least 23000-fold (4.36 log units) between middle value and limit.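

In this assay, the group on this aromatic carbon, para to a large group, turns out to be able to move the result very far: 3-(trifluoromethyl)phenyl in place of 2-fluoro-5-methoxyphenyl gives an at least 20000-fold lower number from compound 2 to compound 3 (4.30 log units; beyond the scatter), and the same group in place of 1H-indol-5-yl gives an at least 20000-fold lower number from compound 1 to compound 3 (4.30 log units; beyond the scatter). As far as these compounds go, compound 3 stands at a limit, < 1.3 nM, and no number is known for it, so the full size of both steps stays unknown. The only earlier step cannot be read, and the series now reaches a limit at each end of this assay: the limit of < 1.3 nM in this assay, at which 1 of the 3 values shown sits.

Compounds 1 and 2 differ from compound 3 in more than one feature of the ring, so the three compounds do not tell whether the trifluoromethyl itself matters or whether the result would hold for a plain phenyl, or for a phenyl carrying a nitrile or a chlorine in place of the trifluoromethyl. From the compounds shown here alone, it also remains open whether the result in this assay would survive a carboxylic acid in place of the ethyl ester at the end of the chain.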